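Swapping ethyl for hydrogen on compound 2

The source may report more compounds than this note shows. Statements on the series, on what has been measured and on what is new or still open speak of the compounds shown alone.

compound 1 `O=C1CS/C(=N/Nc2nncc3ccccc23)N1c1ccccc1`: 32 nM
compound 2 `CCN1C(=O)CS/C1=N/Nc1nncc2ccccc12`: 43 nM
compound 3 `Cc1cc(C)nc(NS(=O)(=O)c2ccc(Nc3nncc4ccccc34)cc2)n1`: 7.9 nM

In a functional assay on COLO 205 cells (Homo sapiens) for antiproliferative activity, read by sulforhodamine B assay, with a stated time of 72 h (on this read-out higher numbers stand for weaker inhibition and lower numbers for stronger inhibition), compound 2 gives 43 nM, within the scatter of compound 1, while compound 3 stands clearly lower at 7.9 nM. Compound 4 `O=C1CS/C(=N/Nc2nncc3ccccc23)N1` has hydrogen in place of ethyl on an amide-type nitrogen in a ring. Going by the values given here, only one measured step touches this nitrogen, and it is a 1.3-fold higher number from compound 1 to compound 2 (0.13 log units; within the scatter), where ethyl takes the place of phenyl. That step stays within the scatter, though it is a different swap and so only a modest guide. In this assay no shift beyond the scatter is therefore expected, and the estimated step is a 1.2-fold higher number from compound 2 to compound 4 (0.07 log units; within the scatter). The expected value for compound 4 is 50 nM, with an estimated range from 20 nM to 130 nM.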

Compound 4, half-maximal inhibitory concentration: 55 nM
The estimate for compound 4 lay 1.1-fold (0.04 log units) below the measured number; the measured number falls inside the stated range.
By their numbers in this assay, from the lowest: compound 3; then compounds 1, 2 and 4 (each within the scatter of the next).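

On the amide-type nitrogen in the ring, hydrogen replacing ethyl gives a 1.3-fold higher number from compound 2 to compound 4 (0.11 log units; within the scatter), and hydrogen replacing phenyl gives a 1.7-fold higher number from compound 1 to compound 4 (0.24 log units; within the scatter). The earlier step only exchanged one carbon group for another, whereas these show that in this assay the nitrogen can carry no carbon group at all and the numbers still stay within the scatter, so hydrogen, ethyl and phenyl are not told apart here. Nothing available explains this result. Still open, going by these compounds, is whether a longer chain, or a chain ending in an amine or a carboxylic acid, on this nitrogen would also stay within the scatter.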